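This account rests on a few compounds, and the source may have more. Where it says the series, first, only, none or still open, it means among the compounds named here.

Compound 1 `COc1cc2cc(Oc3ccc(NC(=O)Nc4ccccc4)cc3)c(C)nc2cc1OC`: in a functional assay on NCI-H226 cells (Homo sapiens) for inhibition, read by sulforhodamine B assay, with a stated time of 48 h, tested at 10 uM (a higher number here means a weaker effect of the compound at the concentration tested, a lower number a stronger effect), compound 1 gives 39.8%.
Compound 2 `COc1cc2cc(Oc3ccc(NC(=O)Nc4ccc(C)cc4)cc3)c(C)nc2cc1OC`: compound 2 gives 102%.
Compound 3 `COc1cc2cc(Oc3ccc(NC(=O)Nc4ccc(C(F)(F)F)cc4)cc3)c(C)nc2cc1OC`: compound 3 gives 20.9%.

Compound 3 has the lowest number of the three, so the strongest effect; the nearest is compound 1 and the furthest compound 2. Compound 4 `COc1cc2cc(Oc3ccc(NC(=O)Nc4ccc(Cl)c(C(F)(F)F)c4)cc3)c(C)nc2cc1OC` is not yet measured. It differs from compound 3 by 4-chloro-3-(trifluoromethyl)phenyl in place of 4-(trifluoromethyl)phenyl on an amide-type nitrogen. The step that bears on it is a number 18.9 percentage points lower from compound 1 to compound 3 (beyond the scatter), which shows that placing trifluoromethyl on this ring lowered the number; a number 81.1 percentage points lower from compound 2 to compound 3 (beyond the scatter) points the same way. The new change keeps trifluoromethyl and adds chlorine, so a small step or none beyond the scatter is expected, with compound 4 estimated at 18% (range 5% to 45%), meaning an expected step of a number 2.9 percentage points lower from compound 3 to compound 4 (within the scatter).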

Compound 4, a percentage reported as activity, at one concentration (the size of the read-out at that concentration, not a potency): 4.49%
Estimate against measurement, compound 4: 13.5 percentage points above; the measured number lies below the stated range.
By their numbers in this assay, from the lowest: compound 4; then compound 3; then compound 1; then compound 2.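

Going from 4-(trifluoromethyl)phenyl to 4-chloro-3-(trifluoromethyl)phenyl on the amide-type nitrogen gives a number 16.4 percentage points lower from compound 3 to compound 4 (beyond the scatter) in this assay and so shows that the number at this position could still fall after trifluoromethyl alone had lowered it. Against the other two, the same group gives a number 35.3 percentage points lower from compound 1 to compound 4 (beyond the scatter) and a number 97.5 percentage points lower from compound 2 to compound 4 (beyond the scatter) which leaves compound 4 with the strongest effect of the four at the concentration tested. No measurement shown accounts for what the added chlorine does. Going by these compounds, whether chlorine on this ring without trifluoromethyl would lower the number stays open, as does what a methoxy group or an amine on the ring would give.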